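Thromboxane receptor antagonists: chain swap on two cores

The compounds below may be only part of what the source reports. "The series", "measured", "known", "first", "only" and "open" are said of these compounds alone.

Measured so far in a functional assay on a cell-free system (plasma) for inhibition of thromboxane A2 receptor (Homo sapiens), read by turbidimetry; on this read-out higher numbers stand for weaker inhibition and lower numbers for stronger inhibition:
- compound 1 `O=C(O)COCCCC[C@H]1[C@H](F)CC[C@@H]1NS(=O)(=O)c1ccc(F)cc1` gives 1800 nM
- compound 2 `O=C(O)COCCCCC1=CCC[C@@H]1NS(=O)(=O)c1ccc(Cl)c(Cl)c1` gives 1900 nM
- compound 3 `O=C(O)CC/C=C\C[C@H]1[C@H](F)CC[C@@H]1NS(=O)(=O)c1ccc(F)cc1` gives 750 nM

Compound 3 arises from compound 1 by 4-carboxybut-1-en-1-yl in place of 3-(carboxymethoxy)propyl on a saturated chain carbon bound to a saturated ring carbon; this gave a 2.4-fold lower number from compound 1 to compound 3 (0.38 log units; beyond the scatter). The difference between the cores of compound 1 and compound 2 is not broken down here; their values in this assay sit within the scatter of each other.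

Compound 4 `O=C(O)CC/C=C\CC1=CCC[C@@H]1NS(=O)(=O)c1ccc(Cl)c(Cl)c1` arises from compound 2 by 4-carboxybut-1-en-1-yl in place of 3-(carboxymethoxy)propyl on a saturated chain carbon bound to a double-bonded ring carbon. The surroundings differ: in compound 1 the chain sits on a saturated chain carbon bound to a saturated ring carbon, in compound 2 on a saturated chain carbon bound to a double-bonded ring carbon, so this is the same kind of change, not the same. A step of a 2.4-fold lower number from compound 2 to compound 4 (0.38 log units; beyond the scatter) is expected, about the size seen from compound 1 to compound 3, resting on one prior instance only. Compound 4 is thus estimated at 800 nM, between 350 nM and 1800 nM.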

Compound 4, half-maximal inhibitory concentration: 1900 nM
For compound 4 the middle estimate is 2.4-fold (0.38 log units) below the measured one, and the stated range ends below it.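

The exchange of 3-(carboxymethoxy)propyl for 4-carboxybut-1-en-1-yl on the core of compound 2 gives no change at the digits printed from compound 2 to compound 4 (within the scatter) in this assay. Set beside the step on the other core, the two results do not separate: the same change on two cores in this assay, a 2.4-fold lower number (0.38 log units; beyond the scatter) from compound 1 to compound 3 and no change at the digits printed (within the scatter) from compound 2 to compound 4, 2.4-fold (0.38 log units) apart, within the scatter of two such steps. The lower number seen on the core of compound 1 is therefore not repeated on the core of compound 2, but a dependence on the core is not shown either, with only one pair on each core.

The compounds shown leave open whether the ring or the halogens on the aryl group govern the size of the step, as these change together between the two cores. Also open, on these data alone, is how a tetrazole in place of the carboxylic acid would read on either core.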